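Notes on three limit values and a fourth compound

The source may report more compounds than this note shows. Statements on the series, on what has been measured and on what is new or still open speak of the compounds shown alone.

Measured so far in a functional assay on HCT-116 cells (Homo sapiens) for inhibition, read by sulforhodamine B assay, with a stated time of 48 h; a lower number here means a stronger inhibitor, a higher number a weaker inhibitor:
compound 1, `COc1ccc(C(c2ccccc2O)c2cccc3ccccc23)c(OC)c1OC`: compound 1 gives > 20000 nM, a limit of the assay rather than a number.
compound 2, `COc1cc(COC(c2ccc(OC)c(OC)c2OC)c2cccc3ccccc23)cc(OC)c1`: compound 2 gives > 20000 nM, likewise a limit.
compound 3, `COc1ccc(C(OCc2ccccc2)c2cccc3ccccc23)c(OC)c1OC`: compound 3 gives > 20000 nM, again a limit.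

Compound 3 therefore stands at no readable point: every value in this series sits at the limit of > 20000 nM in this assay, at which 3 of the 3 values shown sit. The step that the two limits leave unreadable from compound 1 to compound 3 and the step that the two limits leave unreadable from compound 2 to compound 3 both end at that limit, so neither their size nor their direction can be read, and nothing in these data separates any one compound from the other two.

Compound 4, `COC(=O)c1ccc(COC(c2ccc(OC)c(OC)c2OC)c2cccc3ccccc23)cc1`, differs from compound 3 by methoxycarbonyl in place of hydrogen on an aromatic carbon. For the measured compounds named here, no measured step bears on this change, since both steps into compound 3 are unreadable, and the shared core has given no number at all. The expectation for compound 4 is accordingly a value estimated at 30000 nM, with a range from 8000 nM to 120000 nM. The estimated step that the limit leaves unreadable from compound 3 to compound 4 is expected to be none beyond the scatter, and the most probable outcome is that this assay again reports only a limit for compound 4.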

Compound 4, half-maximal inhibitory concentration: > 20000 nM
Compound 4 ended at the assay's limit; the forecaster's own chance of this, stated with the estimate: 80%; the middle value lies beyond the limit too.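

No new step can be read: the steps from compound 2 and from compound 3 to compound 4 both end at the same limit, which is a limit and not a number: the limit of > 20000 nM in this assay, at which 4 of the 4 values shown sit.

The compounds shown leave open whether any change on the shared core gives a number rather than a limit.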